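The source may report more compounds than this note shows. Statements on the series, on what has been measured and on what is new or still open speak of the compounds shown alone.

In a functional assay on NCI-H460 cells (Homo sapiens) for inhibition, read by MTT assay, with a stated time of 4 days (on this read-out higher numbers stand for weaker inhibition and lower numbers for stronger inhibition), compound 1 `COc1ccc(C(=NNC(=O)NNC(=O)NCCCC(C)Nc2cc(OC)cc3cccnc23)c2ccc(OC)cc2)cc1` gives 5000 nM and compound 2 `COc1cc(NC(C)CCCNC(=O)NNC(=O)Nc2ccc(Cl)c(C(F)(F)F)c2)c2ncccc2c1` gives 13000 nM as the higher of the two numbers, a gap beyond the usual scatter. For compound 3 `CCOC(=O)NC(c1ccccc1)c1ccc(Cl)cc1` the reading > 100000 nM is a limit of the assay. Compound 4 `COc1cc(NC(C)CCCNC(=O)NNC(=O)NCCO)c2ncccc2c1` differs from compound 2 in one place, 2-hydroxyethyl in place of 4-chloro-3-(trifluoromethyl)phenyl on an amide-type nitrogen with 2-hydroxyethyl in place of 4-chloro-3-(trifluoromethyl)phenyl on an amide-type nitrogen. Going by the values given here, no measured pair shows this change in this assay so the size of the step is a judgement. With compound 2 at 13000 nM as the reference, a moderate move to a higher number is expected. The expected step is a 2.3-fold higher number from compound 2 to compound 4 (0.36 log units; beyond the scatter) toward weaker inhibition. For compound 4 the estimated value is 30000 nM within an expected range of 10000 nM to 100000 nM in this assay.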

Compound 4, half-maximal inhibitory concentration: > 100000 nM
Compound 4: a limit, no number; the forecaster's own chance of this, stated with the estimate: 25%; middle value at least 3.3-fold (0.52 log units) away from the limit.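

In this assay, 2-hydroxyethyl in place of 4-chloro-3-(trifluoromethyl)phenyl on this amide-type nitrogen gives an at least 7.6-fold higher number from compound 2 to compound 4 (0.88 log units; beyond the scatter), toward weaker inhibition. This shows that the group at this place affects the read-out, and that in this pair the aromatic ring is not replaced by 2-hydroxyethyl without loss. The step has only a lower bound, because the reading of compound 4 is a limit: the limit of > 100000 nM in this assay, at which 2 of the 4 values shown sit.

Going by these compounds, whether the loss follows from the ring leaving or from the hydroxyl entering stays open. An unsubstituted phenyl or a plain ethyl chain on this nitrogen would separate the two.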